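Nitrothiazole amides: nitro to 4-chlorophenyl on the furan

A few compounds are considered here, and "the series" means these few. Any claim that something is new, unique, unknown or untested is made for them only; others in the source may bear on it.

Two compounds of the series carry numbers in an ADME assay on HEK-293T cells (Homo sapiens) for cytotoxicity, read by MTT assay, tested at 25 uM; on this read-out lower numbers stand for a stronger effect and higher numbers for a weaker effect at the one concentration tested. In this assay compound 1 `CC(=O)Oc1ccc(Cl)cc1C(=O)Nc1ncc([N+](=O)[O-])s1` gives 59.5%. Compound 2 `O=C(Nc1ncc([N+](=O)[O-])s1)c1ccc([N+](=O)[O-])o1` gives 87.4%, the higher of the two numbers, and the gap to compound 1 lies beyond the scatter. Within the data shown here, no pair of measured compounds differs in a single place, so no measured step is available for the series.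

Compound 3 `O=C(Nc1ncc([N+](=O)[O-])s1)c1ccc(-c2ccc(Cl)cc2)o1` is the next compound to be measured in this assay. It differs from compound 2 as follows: 4-chlorophenyl in place of nitro on an aromatic carbon. Among the measured compounds shown here, with only two measured compounds and no single-place step between them, the size of the change from compound 2 to compound 3 cannot be read from the data. For the measured compounds named here, the expectation is a moderate step downward, somewhat beyond the scatter, landing between the two numbers known so far. For compound 3 the estimate in this assay is 72%, with a range from 50% to 92%. This corresponds to an expected step of a number 15.4 percentage points lower from compound 2 to compound 3 (beyond the scatter).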

Compound 3, a percentage reported as activity, at one concentration (the size of the read-out at that concentration, not a potency): 75%
Compound 3: middle estimate off by 3 percentage points, on the low side; measured number inside the range.
By their numbers in this assay, from the lowest: compound 1; then compound 3; then compound 2.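

Among these compounds, the first single-place step falls at the aromatic carbon next to the ring oxygen: in this assay the exchange of nitro for 4-chlorophenyl gives a number 12.4 percentage points lower from compound 2 to compound 3 (beyond the scatter) and so moves the read-out toward a stronger effect at the one concentration tested. The position thus accepts a whole six-membered aromatic ring of carbon only in place of nitro, and the step stays modest in size. Nothing measured on these compounds accounts for the step or ties it to any feature of either group.

This single pair cannot separate the loss of nitro from the gain of the 4-chlorophenyl, so a plain phenyl without the chlorine, a methyl or an amine on the same carbon would be needed to tell how much each part contributes. Also open, from the compounds shown here alone, is whether the size of the step depends on the chlorine on the new ring, and whether a carboxylic acid or a longer chain at this carbon would read in the same direction.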